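A few compounds are considered here, and "the series" means these few. Any claim that something is new, unique, unknown or untested is made for them only; others in the source may bear on it.

Measured so far:
compound 1 `CNc1nc2ccccc2c(=O)o1` — in an assay on isolated protein for inhibition of complement C1r subcomponent (Homo sapiens) (a higher number here means a weaker inhibitor, a lower number a stronger inhibitor), compound 1 gives > 62500 nM, which is a limit of the assay.
compound 2 `Cc1cccc2nc(NC(C)C)oc(=O)c12` — in this assay compound 2 gives > 62500 nM, likewise a limit.

Compound 1 therefore stands only at a limit, and the limit of > 62500 nM in this assay, at which 2 of the 2 values shown sit, shows that both measured values sit there. Compound 3 `O=c1oc(Nc2nc[nH]n2)nc2ccccc12` has not yet been measured. It differs from compound 1 by 1H-1,2,4-triazol-3-yl in place of methyl on a nitrogen on an aromatic ring. For the measured compounds named here, no measured pair shows a change of this kind, so the size of the step in this assay cannot be read from the data. The expectation is that compound 3 remains near the limit, the step of an at least 1.2-fold lower number from compound 1 to compound 3 (0.09 log units; that floor lies within the scatter) being estimated as small and of uncertain direction. Compound 3 is expected at 50000 nM, within 5000 nM to 300000 nM.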

Compound 3, half-maximal inhibitory concentration: > 62500 nM
Compound 3 gave a limit, no number; the forecaster's own chance of this, stated with the estimate: 70%; at least 1.2-fold (0.09 log units) between middle value and limit.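

Compound 3, like compound 1, sits at a limit, so the step from methyl to 1H-1,2,4-triazol-3-yl cannot be read: the limit of > 62500 nM in this assay, at which 3 of the 3 values shown sit. The compounds shown leave open whether any change to the shared core gives a measurable value in this assay at all.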